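Anilide variation on the shared core: nitro to trifluoromethyl

The source may hold more compounds than are shown below. What is called first, only, known or untested is meant among the compounds shown, and "the series" means these compounds.

Two compounds of the series carry a number in a functional assay on NCI-H1975 cells (Homo sapiens) for inhibition, read by MTT assay, with a stated time of 72 h; a lower number here means a stronger inhibitor, a higher number a weaker inhibitor. Compound 1 `O=C(CSc1nc(Nc2ccccc2)c2ccccc2n1)Nc1cccc(Cl)c1` gives 8460 nM in this assay, and compound 2 `O=C(CSc1nc(Nc2ccccc2)c2ccccc2n1)Nc1cccc([N+](=O)[O-])c1` gives 17900 nM. Within the data shown here, compound 2 therefore stands at the weaker end of the two, with compound 1 as its only neighbour; the single measured step, a 2.1-fold higher number from compound 1 to compound 2 (0.33 log units; beyond the scatter), is the whole of the comparison so far.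

Compound 3 `O=C(CSc1nc(Nc2ccccc2)c2ccccc2n1)Nc1ccc(C(F)(F)F)cc1` changes the anilide end: 4-(trifluoromethyl)phenyl in place of 3-nitrophenyl on an amide-type nitrogen. Among the measured compounds shown here, the only step that bears on this is the one from compound 1 to compound 2, which replaced one group on that aromatic ring by another and moved the number modestly. For the measured compounds named here, the new change again swaps one substituted phenyl for another on the amide-type nitrogen, so a step of similar size is the most that can be expected; a return toward the number of compound 1 seems more likely than a further rise, but no measured pair settles the direction.

Compound 3 is estimated at 9000 nM in this assay, within 3000 nM to 27000 nM. That estimate means a step of a 2.0-fold lower number from compound 2 to compound 3 (0.30 log units; within the scatter), expected to be near the edge of the scatter.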

Compound 3, half-maximal inhibitory concentration: 11700 nM
The estimate for compound 3 lay 1.3-fold (0.11 log units) below the measured number; low and high end bracket the measured number.
By their numbers in this assay, from the lowest: compounds 1, 3 and 2 (each within the scatter of the next, the first and the last beyond it).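

In this assay, 4-(trifluoromethyl)phenyl in place of 3-nitrophenyl on the amide-type nitrogen gives a 1.5-fold lower number from compound 2 to compound 3 (0.18 log units; within the scatter) and the same group in place of 3-chlorophenyl gives a 1.4-fold higher number from compound 1 to compound 3 (0.14 log units; within the scatter) so compound 3 cannot be separated from either of the other two compounds, although the step of a 2.1-fold higher number from compound 1 to compound 2 (0.33 log units; beyond the scatter) lies beyond the scatter. At this position, a change of both the substituent and its printed ring number therefore produced no step beyond the scatter, and the two parts of that change cannot be told apart with these three compounds. No measurement available here accounts for the numbers of this series.

Among these compounds, still open is how 3-(trifluoromethyl)phenyl or 4-nitrophenyl would compare on the same amide-type nitrogen, as either would change only one part of the exchange seen in compound 3. Also open, going by these compounds, is whether an amine or a carboxylic acid on this phenyl ring, or an unsubstituted phenyl there, would move the number beyond the narrow range seen so far.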